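Replacing Methyl with Phenyl at the Chain End

The source may hold more compounds than are shown below. What is called first, only, known or untested is meant among the compounds shown, and "the series" means these compounds.

Compound 1, `CCCCCCCCC#CCOCc1cccc(CCC(=O)O)c1`: 10000 nM
Compound 2, `CCCCCCC#CCOCc1cccc(CCC(=O)O)c1`: a limit, > 10000 nM

In an assay on isolated protein for inhibition of Arachidonate 12-lipoxygenase (Sus scrofa) (on this read-out lower numbers stand for stronger inhibition and higher numbers for weaker inhibition), compound 1 gives 10000 nM. For compound 2 the reading is only a limit of the assay, > 10000 nM, so the number itself is not known. The single measured step, a number no lower from compound 1 to compound 2 (the limit leaves the size open), therefore has no readable size; all that can be said is that inhibition did not strengthen when the chain was shortened, as shown by the limit of > 10000 nM in this assay, at which 1 of the 2 values shown sits.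

Compound 3, `O=C(O)CCc1cccc(COCC#CCCCCCc2ccccc2)c1`, has not been measured. It differs from compound 2 by phenyl in place of methyl on a saturated chain carbon, five bonds along the chain from a triple-bonded carbon. The phenyl extends the end of the chain, as the ethyl of compound 1 did relative to compound 2, and compound 1 itself reached only 10000 nM. With compound 2 at the limit and the measured step unreadable, the expected step of a number no higher from compound 2 to compound 3 (the limit leaves the size open) from compound 2 to compound 3 is small, within the usual scatter, and weak inhibition is expected either way. For compound 3 the estimate is 10000 nM, with a range from 3000 nM to 30000 nM.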

Compound 3, half-maximal inhibitory concentration: 5000 nM
Beside the measured number, compound 3's estimate is 2.0-fold (0.30 log units) above it, and the stated range covers the measured number.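

Compound 3 shows that a phenyl can stand at this place, five bonds along the chain from a triple-bonded carbon, and still give a readable number. Compound 2, with methyl there, gives only a limit of the assay: the limit of > 10000 nM in this assay, at which 1 of the 3 values shown sits.

In this assay the change from methyl to phenyl is an at least 2.0-fold lower number from compound 2 to compound 3 (0.30 log units; that floor lies within the scatter), so only a floor on its size is known, and that floor does not separate the two compounds. The comparison with the longer chain is a 2.0-fold lower number from compound 1 to compound 3 (0.30 log units; within the scatter), so the phenyl of compound 3 and the propyl it replaces in compound 1 cannot be told apart on this read-out.

From the compounds shown here alone, it remains open whether the ring itself matters or whether any larger group at the chain end would serve equally well, and a cyclohexyl in place of the phenyl would address that. Also open, going by these compounds, is whether a substituted ring, such as a chlorophenyl or a methoxyphenyl, or a pyridine ring would move the number beyond the usual scatter.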